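Cytotoxicity notes on two amides and a third

The compounds below may be only part of what the source reports. "The series", "measured", "known", "first", "only" and "open" are said of these compounds alone.

Measured so far:
compound 1 `Cc1ccccc1C(=O)N(Cc1ccco1)Cc1cc2cccc(C)c2[nH]c1=O` – > 64700 nM
compound 2 `Cc1cccc2cc(CN(Cc3ccco3)C(=O)c3ccccc3F)c(=O)[nH]c12` – > 64000 nM

In an ADME assay on MT2 cells (Homo sapiens) for cytotoxicity, read by XTT assay, with a stated time of 4 days (on this read-out lower numbers stand for higher toxicity in this test and higher numbers for lower toxicity in this test), compound 1 reaches only the limit > 64700 nM. Compound 2 likewise gives only the limit > 64000 nM in this assay. The step that the two limits leave unreadable from compound 1 to compound 2 cannot be read, since both values sit at the ceiling of the test (the limit of > 64000 nM in this assay, at which 1 of the 2 values shown sits, (the limit of > 64700 nM in this assay, at which 1 of the 2 values shown sits)). Compound 3 `Cc1ccc(C(=O)N(Cc2ccco2)Cc2cc3cccc(C)c3[nH]c2=O)cc1` is not yet measured; it differs from compound 2 by 4-methylphenyl in place of 2-fluorophenyl on a carbonyl carbon. Among the measured compounds shown here, no measured step bears on this change. Compound 2 stands at a limit. Compound 3 is expected to stay there, an expected step that the limit leaves unreadable from compound 2 to compound 3 not readable beyond the scatter. The estimate for compound 3 in this assay is 70000 nM, between 30000 nM and 200000 nM.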

Compound 3, half-maximal cytotoxic concentration: 9200 nM
Compound 3: middle estimate off by 7.6-fold (0.88 log units), on the high side; the whole stated range lies above it.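

The aryl group on the carbonyl carbon can move the number in this assay: 4-methylphenyl in place of 2-fluorophenyl gives an at least 6.9-fold lower number from compound 2 to compound 3 (0.84 log units; beyond the scatter) and 4-methylphenyl in place of 2-methylphenyl gives an at least 7.0-fold lower number from compound 1 to compound 3 (0.84 log units; beyond the scatter). Neither step has a fixed size, since compound 2 stands at a limit: the limit of > 64000 nM in this assay, at which 1 of the 3 values shown sits. Compound 1 also stands at a limit: the limit of > 64700 nM in this assay, at which 1 of the 3 values shown sits.

As far as these compounds go, whether the higher toxicity in this test belongs to 4-methylphenyl alone stays open. Also open, from the compounds shown here alone, is how a 4-fluorophenyl group, or a phenyl group carrying an amine or a carboxylic acid, would read at this position.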